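The source may report more compounds than this note shows. Statements on the series, on what has been measured and on what is new or still open speak of the compounds shown alone.

Compounds and their results in an ADME assay (liver, Mus musculus) for metabolic stability, using microsomes, with a stated time of 10 min; a higher number here means that more of the compound is left, a lower number that less of the compound is left:
- compound 1 `CCCS(=O)(=O)N1CC=C(c2ccc3c(c2)CC(C2CCN(C(=O)OC(C)C)CC2)O3)CC1`: 12%
- compound 2 `CCCS(=O)(=O)N1CC=C(c2ccc3c(c2)CC(C2CCN(C(=O)OC4CCCCC4)CC2)O3)CC1`: "not determined" (no result reported)
- compound 3 `CCCS(=O)(=O)N1CC=C(c2ccc3c(c2)CC(C2CCN(c4ncc(Cl)cn4)CC2)O3)CC1`: 45%

Of the two compounds with a number, compound 1 stands lowest at 12%, and compound 3 is the nearest at 45%. Compound 2 offers no number for comparison.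

Compound 4 `CCCS(=O)(=O)N1CC=C(c2ccc3c(c2)CC(C2CCN(c4ccc(C(F)(F)F)cn4)CC2)O3)CC1` has not yet been measured in this assay. It departs from compound 1 by a single change: 5-(trifluoromethyl)pyridin-2-yl in place of isopropoxycarbonyl on an amine nitrogen in a ring. For the measured compounds named here, one measured step bears on this change. It also removes isopropoxycarbonyl from an amine nitrogen in a ring, but puts 5-chloropyrimidin-2-yl there instead: a number 33 percentage points higher from compound 1 to compound 3 (beyond the scatter), a large step beyond the scatter. Going by the values given here, that step is the only guide, and the data hold no measurement of 5-(trifluoromethyl)pyridin-2-yl itself, so its size can carry over only loosely. Among the compounds with values here, a large upward step is therefore expected, of about the same order as the one seen with compound 3, though with considerable uncertainty. The expected step is a number 28 percentage points higher from compound 1 to compound 4 (beyond the scatter). For compound 4 the estimated value is 40%. The expected range for compound 4 runs from 20% to 65%.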

Compound 4, percent of the compound remaining: 46%
Beside the measured number, compound 4's estimate is 6 percentage points below it; low and high end bracket the measured number.
By their numbers in this assay, from the lowest: compound 1; then compounds 3 and 4 (each within the scatter of the next).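

In this assay, 5-(trifluoromethyl)pyridin-2-yl in place of isopropoxycarbonyl on the amine nitrogen in a ring gives a number 34 percentage points higher from compound 1 to compound 4 (beyond the scatter), so a large upward step at this position is no longer tied to 5-chloropyrimidin-2-yl alone. Exchanging one of these aromatic groups for the other gives a number 1 percentage points higher from compound 3 to compound 4 (within the scatter), so this assay does not separate them, even though they differ both in the ring itself and in whether it carries chloro or trifluoromethyl. Nothing measured here speaks to why the number rises at this position.

The compounds shown leave open whether a plain phenyl group, a pyridin-2-yl group with no trifluoromethyl, or a benzyl group on that same nitrogen would reach the level of compound 3 and compound 4, or whether the ring needs a chloro or trifluoromethyl substituent at all. They also leave open whether an amide or a urea in place of the isopropoxycarbonyl would stay close to compound 1 or move towards the two aromatic examples.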